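This account rests on a few compounds, and the source may have more. Where it says the series, first, only, none or still open, it means among the compounds named here.

Measured so far:
compound 1 `N#Cc1ccccc1CN1C(=O)N(Cc2ccccc2)S(=O)(=O)n2cccc21`: > 318000 nM
compound 2 `O=C1N(Cc2ccccc2Cl)c2cccn2S(=O)(=O)N1Cc1cccc(F)c1`: 231000 nM

In an ADME assay on MT4 cells (Homo sapiens) for cytotoxicity, read by MTT assay, with a stated time of 5 days (on this read-out lower numbers stand for higher toxicity in this test and higher numbers for lower toxicity in this test), compound 1 gives only a limit, > 318000 nM, and no number. Compound 1 therefore sits at the limit of > 318000 nM in this assay, at which 1 of the 2 values shown sits, so its true value is not pinned down. Compound 2 gives 231000 nM in this assay. Compound 3 `O=C1N(Cc2cccc(Cl)c2)c2cccn2S(=O)(=O)N1Cc1ccccc1` differs from compound 1 by 3-chlorophenyl in place of 2-cyanophenyl on a saturated chain carbon bound to an amide-type nitrogen in a ring. Going by the values given here, no step between measured compounds is known, so in this assay only a small shift, if any beyond the usual scatter, is expected. Compound 3 is expected to give about 300000 nM, likely between 150000 nM and 600000 nM. The expected step is an at least 1.0-fold lower number from compound 1 to compound 3 (0.02 log units; that floor lies within the scatter).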

Compound 3, half-maximal cytotoxic concentration: 196000 nM
Compound 3: middle estimate off by 1.5-fold (0.18 log units), on the high side; measured number inside the range.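

Replacing 2-cyanobenzyl with 3-chlorobenzyl, on the amide-type nitrogen in a ring, gives in this assay an at least 1.6-fold lower number from compound 1 to compound 3 (0.21 log units; that floor lies within the scatter). This step is only a floor, because compound 1 gives a limit and not a number: the limit of > 318000 nM in this assay, at which 1 of the 3 values shown sits. At this place, compound 3 gives a measured number, 196000 nM, so the change brings the read-out within measurable range. The step alone does not establish a real shift.

On these data alone, the true size of the step remains open. So does whether an amine or a carboxylic acid at this place would shift the number beyond the usual scatter.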